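Aryl ketone para substituent in a dibromo-aryl ether series

A few compounds are considered here, and "the series" means these few. Any claim that something is new, unique, unknown or untested is made for them only; others in the source may bear on it.

Measured compounds:
compound 1, `Cc1ccc(C(=O)/C=C/c2cc(Br)cc(Br)c2Oc2c([N+](=O)[O-])cc(C(F)(F)F)cc2[N+](=O)[O-])cc1`, 10.1 ug/mL
compound 2, `Cc1ccc(C(=O)/C=C/c2cccc(Br)c2Oc2c([N+](=O)[O-])cc(C(F)(F)F)cc2[N+](=O)[O-])cc1`, 6.85 ug/mL
compound 3, `O=C(/C=C/c1cccc(Br)c1Oc1c([N+](=O)[O-])cc(C(F)(F)F)cc1[N+](=O)[O-])c1ccc(Cl)cc1`, 16.5 ug/mL

In a functional assay on A549 cells (Homo sapiens) for antiproliferative activity, read by MTT assay, with a stated time of 48 h (on this read-out higher numbers stand for weaker inhibition and lower numbers for stronger inhibition), compound 1 gives 10.1 ug/mL, the second highest of the three numbers; compound 2 at 6.85 ug/mL sits within the scatter of it, and compound 3 at 16.5 ug/mL is also within the scatter of it, so no order among the three is claimed.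

Compound 4, `O=C(/C=C/c1cc(Br)cc(Br)c1Oc1c([N+](=O)[O-])cc(C(F)(F)F)cc1[N+](=O)[O-])c1ccc(Br)cc1`, is not yet measured. It differs from compound 1 by bromo in place of methyl on an aromatic carbon. Of the measured steps, a 1.5-fold lower number from compound 1 to compound 2 (0.17 log units; within the scatter) concerns a different place and does not bear on this change. The step of a 2.4-fold higher number from compound 2 to compound 3 (0.38 log units; beyond the scatter) exchanges the same methyl for a halogen at the same place, and bromo is the halogen nearest chloro among those shown; it is the only step that bears on the change. A step of similar size toward a higher number is therefore expected, a 2.0-fold higher number from compound 1 to compound 4 (0.30 log units; within the scatter), with the caution that it rests on a single pair.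

For compound 4 in this assay the estimate is 20 ug/mL, with a range from 9 ug/mL to 45 ug/mL.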

Compound 4, half-maximal inhibitory concentration: 16.8 ug/mL
For compound 4 the middle estimate is 1.2-fold (0.08 log units) above the measured one, and the stated range covers the measured number.
By their numbers in this assay, from the lowest: compounds 2, 1, 3 and 4 (each within the scatter of the next, the first and the last beyond it).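

On the core of compound 1, bromo in place of methyl at this place gives a 1.7-fold higher number from compound 1 to compound 4 (0.22 log units; within the scatter) in this assay, so this exchange of methyl for a halogen does not separate from the usual scatter here. Among the compounds shown here, the only earlier step of this type, a 2.4-fold higher number from compound 2 to compound 3 (0.38 log units; beyond the scatter), lay on the core of compound 2 with chloro as the entering group and was beyond the scatter, so that result cannot be taken as a general halogen-for-methyl effect across both cores. Nothing shown offers a reason for this result.

Bromo and chloro at this place remain uncompared on a single core, as compound 3 and compound 4 differ in more than one place. Also open, going by these compounds, is whether an amine or a carboxylic acid on this aromatic carbon would give a step beyond the scatter.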